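The compounds below may be only part of what the source reports. "The series", "measured", "known", "first", "only" and "open" are said of these compounds alone.

Measured in an ADME assay on the whole organism (plasma, strain 129/SvEvBrd x C57BL/6) for pharmacokinetics, with Mus musculus as the target, at a dose of 10 mg/kg by the oral route; a lower number here means less compound in the circulation, a higher number more compound in the circulation at the dose given:
- Compound 1 `CC(F)(F)c1nc([C@@H](O)[C@H](O)[C@H](O)CO)c[nH]1`: 1190 ng.h/mL
- Compound 2 `OC[C@@H](O)[C@@H](O)[C@H](O)c1c[nH]c(-c2ncccn2)n1`: 799 ng.h/mL
- Compound 3 `OC[C@@H](O)[C@@H](O)[C@H](O)c1c[nH]c(-c2cnccn2)n1`: 1250 ng.h/mL

Compound 3 stands level with the other two, as neither of its steps leaves the scatter: a 1.1-fold higher number from compound 1 to compound 3 (0.02 log units; within the scatter) and a 1.6-fold higher number from compound 2 to compound 3 (0.19 log units; within the scatter).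

Compound 4 `Cn1cnc(-c2nc([C@@H](O)[C@H](O)[C@H](O)CO)c[nH]2)c1` has not yet been measured. It carries 1-methyl-1H-imidazol-4-yl in place of pyrazin-2-yl on an aromatic carbon, between two ring nitrogen atoms: 1-methyl-1H-imidazol-4-yl in place of pyrazin-2-yl on an aromatic carbon.

Among the compounds with values here, the steps that bear on this change are those made at the same place on the shared core. Besides the two above, there is a 1.5-fold lower number from compound 1 to compound 2 (0.17 log units; within the scatter). All three are small, so exchanging the group at this place has not yet moved the number measurably. Within the data shown here, none of the measured compounds carries 1-methyl-1H-imidazol-4-yl, so the new group remains untested and the range stays wide.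

In this assay, no change beyond the scatter is expected, and the estimated step is a 1.3-fold lower number from compound 3 to compound 4 (0.10 log units; within the scatter). Compound 4 is expected at about 1000 ng.h/mL, with an estimated range from 450 ng.h/mL to 2200 ng.h/mL.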

Compound 4, area under the concentration-time curve: 698 ng.h/mL
Compound 4: the middle estimate sits 1.4-fold (0.16 log units) above what was measured; the range from low to high includes it.
By their numbers in this assay, from the lowest: compounds 4, 2, 1 and 3 (each within the scatter of the next).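

Compound 4 puts a five-membered aromatic ring, 1-methyl-1H-imidazol-4-yl, at this place, where the earlier groups were pyrazin-2-yl, pyrimidin-2-yl and 1,1-difluoroethyl. In this assay this new group cannot be told apart from any of them, as all three new steps stay within the scatter (a 1.8-fold lower number from compound 3 to compound 4 (0.25 log units; within the scatter); a 1.1-fold lower number from compound 2 to compound 4 (0.06 log units; within the scatter); a 1.7-fold lower number from compound 1 to compound 4 (0.23 log units; within the scatter)), so changing from a six-membered to a five-membered ring has shown no measurable effect here. No measurement at hand offers an explanation for this result.

From the compounds shown here alone, it remains open whether a different kind of group at this place, such as an amine or a carboxylic acid, would move the number beyond the scatter. Also open, going by these compounds, is how much changes to the rest of the shared core, which is the same in all four compounds, would matter.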